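The source may report more compounds than this note shows. Statements on the series, on what has been measured and on what is new or still open speak of the compounds shown alone.

In an assay for binding affinity to melatonin receptor (Gallus gallus) (on this read-out lower numbers stand for stronger inhibition and higher numbers for weaker inhibition), three compounds have been measured so far. Compound 1 `CCC(=O)NCCCc1ccc(OC)cc1` gives 2900 nM in this assay. Compound 2 `CCCC(=O)NCCCc1ccc(OC)cc1` gives 860 nM. The two differ by methyl in place of hydrogen on a saturated chain carbon, two bonds along the chain from a carbonyl carbon, and this assay shows a 3.4-fold lower number from compound 1 to compound 2 (0.53 log units; beyond the scatter). Compound 3 `CCC(=O)NCCCCc1ccccc1OC` is built on another core; how its core differs from that of compound 1 is not broken down here. In this assay compound 3 gives 339 nM, the lowest of the three numbers, beyond the scatter from compound 2 and from compound 1.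

Compound 4 `CCCC(=O)NCCCCc1ccccc1OC` has not yet been measured in this assay. It differs from compound 3 by methyl in place of hydrogen on a saturated chain carbon, two bonds along the chain from a carbonyl carbon, the same change, at the same place, that turns compound 1 into compound 2. The step expected in this assay is a 2.8-fold lower number from compound 3 to compound 4 (0.45 log units; beyond the scatter), which rests on the measured step of a 3.4-fold lower number from compound 1 to compound 2 (0.53 log units; beyond the scatter), applied to the value of compound 3, 339 nM. Compound 4 is therefore estimated to give 120 nM in this assay, with a likely range from 50 nM to 300 nM.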

Compound 4, inhibition constant: 116 nM
The estimate for compound 4 lay 1.0-fold (0.01 log units) above the measured number, within the range that was stated.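

Carrying methyl in place of hydrogen onto the core of compound 3, on a saturated chain carbon two bonds along the chain from a carbonyl carbon, gives a 2.9-fold lower number from compound 3 to compound 4 (0.47 log units; beyond the scatter) in this assay. Set beside the earlier step, the change keeps its size on the two cores: the same change on two cores in this assay, a 3.4-fold lower number (0.53 log units; beyond the scatter) from compound 1 to compound 2 and a 2.9-fold lower number (0.47 log units; beyond the scatter) from compound 3 to compound 4, 1.2-fold (0.06 log units) apart, within the scatter of two such steps

This shows that, for these two pairs, the step carries over from one core to the other at about the same size, but two pairs make no rule for the whole series, and they do not show why the number falls or how the change would behave on any further core.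

The compounds shown stop at the propylcarbonyl group, so it remains open whether a longer chain, a branched chain or a cyclopropyl group in its place would continue the trend. Equally open, on these data alone, is whether a hydroxyl group or a fluorine atom on that same saturated chain carbon would give a step like these two.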